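A few compounds are considered here, and "the series" means these few. Any claim that something is new, unique, unknown or untested is made for them only; others in the source may bear on it.

Compound 1 `COc1ccc(C(=O)NC[C@H]2c3[nH]c4ccccc4c3C[C@H]3[C@H]4c5[nH]c6ccccc6c5C[C@@H]([C@H](C#N)N23)N4C)cc1` gives 310 nM in a functional assay on HepG2 cells (Homo sapiens) for cytotoxicity, read by MTT assay, with a stated time of 72 h; on this read-out higher numbers stand for weaker inhibition and lower numbers for stronger inhibition. Compound 2 `CN1[C@@H]2c3[nH]c4ccccc4c3C[C@H]1[C@H](C#N)N1[C@@H](CNC(=O)c3ccc(F)cc3)c3[nH]c4ccccc4c3C[C@@H]21` gives 210 nM in this assay, and compound 3 `CCc1ccc(C(=O)NC[C@H]2c3[nH]c4ccccc4c3C[C@H]3[C@H]4c5[nH]c6ccccc6c5C[C@@H]([C@H](C#N)N23)N4C)cc1` gives 570 nM in this assay, the highest of the three numbers. The steps within this set are a 1.5-fold lower number from compound 1 to compound 2 (0.17 log units; within the scatter), a 1.8-fold higher number from compound 1 to compound 3 (0.26 log units; within the scatter) and a 2.7-fold higher number from compound 2 to compound 3 (0.43 log units; beyond the scatter), all exchanges of one group on an aromatic carbon.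

Compound 4 `CN1[C@@H]2c3[nH]c4ccccc4c3C[C@H]1[C@H](C#N)N1[C@@H](CNC(=O)c3cccc4c3CCCC4)c3[nH]c4ccccc4c3C[C@@H]21` is not yet measured; it differs from compound 3 by 1,2,3,4-tetrahydronaphthalen-5-yl in place of 4-ethylphenyl on a carbonyl carbon. Going by the values given here, no measured step covers a change of this kind, so the three exchanges on the aromatic carbon bear only indirectly, and they cover a narrow spread. For this assay a step of no more than the scatter is therefore expected, a 1.1-fold higher number from compound 3 to compound 4 (0.06 log units; within the scatter). Compound 4 is estimated at 650 nM, with a range from 250 nM to 1700 nM.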

Compound 4, half-maximal inhibitory concentration: 540 nM
Compound 4: middle estimate off by 1.2-fold (0.08 log units), on the high side; the range from low to high includes it.
By their numbers in this assay, from the lowest: compounds 2, 1, 4 and 3 (each within the scatter of the next, the first and the last beyond it).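

In this assay, the carbonyl carbon accepts 1,2,3,4-tetrahydronaphthalen-5-yl, with its extra non-aromatic ring, at no measurable cost against 4-ethylphenyl (a 1.1-fold lower number from compound 3 to compound 4 (0.02 log units; within the scatter)) or 4-methoxyphenyl (a 1.7-fold higher number from compound 1 to compound 4 (0.24 log units; within the scatter)). Going by these compounds alone, only 4-fluorophenyl separates from it (a 2.6-fold higher number from compound 2 to compound 4 (0.41 log units; beyond the scatter)), and that modest gap is the sole step here beyond the scatter for a change of the whole group on the carbonyl carbon. No evidence is at hand that explains these steps.

Open, going by these compounds, is whether cyclohexyl, with no aromatic ring, holds the value on this carbonyl carbon. Also open, on these data alone, is what an aminomethyl or carboxylic acid group on the aromatic ring would do.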